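The source may report more compounds than this note shows. Statements on the series, on what has been measured and on what is new or still open speak of the compounds shown alone.

Working notes on the series. For the measured compounds named here, in a functional assay on DU-145 cells (Homo sapiens) for inhibition, read by MTT assay, with a stated time of 48 h (a lower number here means a stronger inhibitor, a higher number a weaker inhibitor), compound 1 (`CCn1c(/C=C2\SC(=O)N(CC(=O)N3CCCC3)C2=O)nc2ccccc21`) gives 45100 nM, the only reading so far that is not a limit. Compound 2 (`CC(C)n1c(/C=C2\SC(=O)N(CC(=O)N3CCOCC3)C2=O)nc2ccccc21`) reads > 50000 nM, which is a limit. Compound 3 (`CCn1c(/C=C2\SC(=O)N(CC(=O)N3CC(C)OC(C)C3)C2=O)nc2ccccc21`) reads > 50000 nM, also a limit. Compound 3 therefore has no number of its own and stands at the limit of > 50000 nM in this assay, at which 2 of the 3 values shown sit.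

The next structure is compound 4 (`CCn1c(/C=C2\SC(=O)N(CC(=O)N3CCOCC3)C2=O)nc2ccccc21`), with morpholin-4-yl in place of 2,6-dimethylmorpholin-4-yl on a carbonyl carbon.

Going by the values given here, the one measured step at this carbonyl carbon is an at least 1.1-fold higher number from compound 1 to compound 3 (0.04 log units; that floor lies within the scatter). Going by these compounds, it replaces pyrrolidin-1-yl with 2,6-dimethylmorpholin-4-yl, and its floor gives no sign of a change beyond the scatter, although its true size stays open. Compound 2, which also holds morpholin-4-yl on that carbonyl carbon, sits at > 50000 nM, again a limit.

On this basis no step beyond the scatter is expected in this assay, in either direction. The estimated step is a step that the limit leaves unreadable from compound 3 to compound 4. Compound 4 is expected at 55000 nM, with an estimated range from 30000 nM to 100000 nM. A reading that is again only a limit is the more likely outcome.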

Compound 4, half-maximal inhibitory concentration: > 50000 nM
Compound 4 gave a limit, no number (the forecaster's own chance of this, stated with the estimate: 70%); the middle value lies beyond the limit too.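

In this assay, compound 4, with morpholin-4-yl on the carbonyl carbon, gives a limit and not a number, so removing the two methyl groups of 2,6-dimethylmorpholin-4-yl brings no reading into the measurable range. Morpholin-4-yl in place of pyrrolidin-1-yl at this carbonyl carbon gives an at least 1.1-fold higher number from compound 1 to compound 4 (0.04 log units; that floor lies within the scatter), and the true size of this step stays open. The steps to compound 4 from compound 2 and compound 3 cannot be read, and the series now gathers at a single limit: the limit of > 50000 nM in this assay, at which 3 of the 4 values shown sit.

Open, going by these compounds, is whether a group such as piperidin-1-yl, 4-methylpiperazin-1-yl or an open-chain diethylamino on this carbonyl carbon would give a reading clearly apart from that of compound 1. Also open, on these data alone, is how far compound 2, compound 3 and compound 4 lie from compound 1, and whether they differ from one another at all.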